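Moving the chlorine on the aryl ether of compound 3

This account rests on a few compounds, and the source may have more. Where it says the series, first, only, none or still open, it means among the compounds named here.

Among the measured compounds shown here, compound 3 `O=C(O)C[C@@H]1CCCN1c1ccc(Oc2cccc(Cl)c2)cc1` gives 680 nM in a functional assay on cells for agonist activity at Free fatty acid receptor 1 (Homo sapiens), read by FLIPR and calcium flux, with a stated time of 100 s (on this read-out lower numbers stand for an effect already at smaller amounts and higher numbers for an effect only at larger amounts of compound), the highest of the three numbers measured so far. Compound 1 `Cc1ccccc1COc1ccc(N2CCC[C@H]2CC(=O)O)cc1` gives 190 nM and compound 2 `Cc1ccccc1Oc1ccc(N2CCC[C@H]2CC(=O)O)cc1` gives 74 nM; the steps of a 3.6-fold higher number from compound 1 to compound 3 (0.55 log units; beyond the scatter) and a 9.2-fold higher number from compound 2 to compound 3 (0.96 log units; beyond the scatter) both point the same way, leaving compound 3 at the weak end of the set. Compound 4 `O=C(O)C[C@@H]1CCCN1c1ccc(Oc2ccc(Cl)cc2)cc1` carries 4-chlorophenyl in place of 3-chlorophenyl on an oxygen on an aromatic ring. For the measured compounds named here, none of the measured steps, including a 2.6-fold lower number from compound 1 to compound 2 (0.41 log units; beyond the scatter), changes only where a chlorine sits, so they bear on this step only loosely and no direction can be read from them. The expected step is a 1.0-fold lower number from compound 3 to compound 4 (0.02 log units; within the scatter), not beyond the scatter. Compound 4 is estimated at 650 nM in this assay, with a range from 250 nM to 1800 nM.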

Compound 4, half-maximal effective concentration: 290 nM
For compound 4 the middle estimate is 2.2-fold (0.35 log units) above the measured one; the range from low to high includes it.
By their numbers in this assay, from the lowest: compound 2; then compounds 1 and 4 (each within the scatter of the next); then compound 3.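

In this assay, among the compounds shown here, the place of the chlorine matters: 4-chlorophenyl in place of 3-chlorophenyl gives a 2.3-fold lower number from compound 3 to compound 4 (0.37 log units; beyond the scatter) and is the only step so far that moves the chlorine alone. Even so, the change from 2-methylphenyl to 4-chlorophenyl gives a 3.9-fold higher number from compound 2 to compound 4 (0.59 log units; beyond the scatter) as a clear loss, whereas the change from 2-methylbenzyl gives a 1.5-fold higher number from compound 1 to compound 4 (0.18 log units; within the scatter) and so no real difference. Nothing at hand explains why the chlorine's place matters. From the compounds shown here alone, whether a 2-chlorophenyl or a 4-methylphenyl group on that oxygen would reach the level of the 2-methylphenyl group stays open.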